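The source may hold more compounds than are shown below. What is called first, only, known or untested is meant among the compounds shown, and "the series" means these compounds.

Of the compounds shown here, two with a shared core have been measured in an ADME assay on BTI cells for inhibition of Amine oxidase [flavin-containing] A (Homo sapiens), read by fluorescence and Amplex Red, with a stated time of 15 min, tested at 100 uM; on this read-out higher numbers stand for more inhibition at the one concentration tested (going by the name of the read-out) and lower numbers for less inhibition. Compound 1, `C#CCN(C)CCCCOc1ccc(C(C)=O)cc1OC`, gives 21.1% in this assay. Compound 2, `C#CCN(C)CCCCOc1ccc(C=O)c(OC)c1`, gives 29.4% in this assay. The gap between these two numbers lies within the usual scatter of repeated measurements, so compound 2 cannot be set apart from compound 1 on the numbers shown; both sit in a modest range of inhibition at the single concentration tested.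

Compound 3, `C#CCN(C)CCCCCCOc1ccc(C=O)c(OC)c1`, has not yet been measured. It differs from compound 2 by 2-(methyl(propargyl)amino)ethyl in place of methyl(propargyl)amino on a saturated chain carbon, four bonds along the chain from an oxygen on an aromatic ring. The structural change is a longer saturated chain carrying the same amine, with no new ring, no new donor and no new acceptor.

For the measured compounds named here, no measured pair here shows what a step of this kind does, so the expectation for compound 3 rests on the two numbers alone, which sit close together. A step of a number 0.6 percentage points higher from compound 2 to compound 3 (within the scatter) is expected, that is, a change not beyond the scatter of this assay. Compound 3 is therefore estimated to give 30% in this assay, with a range from 10% to 50%.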

Compound 3, a percentage reported as inhibition, at one concentration (the size of the read-out at that concentration, not a potency): 37.4%
For compound 3 the middle estimate is 7.4 percentage points below the measured one; measured number inside the range.
By their numbers in this assay, from the lowest: compounds 1, 2 and 3 (each within the scatter of the next, the first and the last beyond it).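

In this assay, for the compounds shown here, compounds 2 and 3 form the first measured pair that differs in one place only, which gives a direct reading of a single change on the saturated chain. Placing 2-(methyl(propargyl)amino)ethyl where methyl(propargyl)amino stood, four bonds along the chain from an oxygen on an aromatic ring, gives a number 8 percentage points higher from compound 2 to compound 3 (within the scatter) and so does not set the two compounds apart: the longer chain carrying the same amine keeps a reading that cannot be told from that of the shorter chain. No data here bear on what lies behind this result.

Because this is a single step that stays within the scatter, it cannot show whether chain length matters at all in this series, and a still longer chain, or a shorter one, would be needed to test whether any real trend exists. Also open, on these data alone, is what happens when the methyl(propargyl)amino end is replaced by a different amine, such as dimethylamino, on this same chain, or when the aldehyde carbonyl on the shared core gives way to a carboxylic acid.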